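Dichlorophenyl for Difluorophenyl: Expecting No Move

The source may hold more compounds than are shown below. What is called first, only, known or untested is meant among the compounds shown, and "the series" means these compounds.

Measured compounds in a functional assay on PANC-1 cells (Homo sapiens) for inhibition, read by MTT assay, with a stated time of 24 h, tested at 10 uM; a higher number here means more inhibition at the concentration tested (going by the name of the read-out), a lower number less inhibition:
Compound 1 `CC(C)=CCOc1cc(=O)n(CCCO)c2c1CC(CC=C(C)C)C(C)(C)C2` gives 7.5%.
Compound 2 `COc1ccc(NC(=O)Oc2cc(=O)n(CCCO)c3c2CC(CC=C(C)C)C(C)(C)C3)cc1` gives 0%.
Compound 3 `CC(C)=CCC1Cc2c(OC(=O)Nc3ccc(F)cc3F)cc(=O)n(CCCO)c2CC1(C)C` gives 0%.

Compound 3 stands level with compound 2 at the digits shown, and together the two are the lowest of the three numbers. Its furthest neighbour is compound 1, yet even that gap, a number 7.5 percentage points lower from compound 1 to compound 3 (within the scatter), lies within the scatter. Put plainly, none of the three compounds can be told apart from the others in this assay.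

Compound 4 `CC(C)=CCC1Cc2c(OC(=O)Nc3ccc(Cl)c(Cl)c3)cc(=O)n(CCCO)c2CC1(C)C` differs from compound 3 in one place: 3,4-dichlorophenyl in place of 2,4-difluorophenyl on an amide-type nitrogen. The measured step that bears most directly on this change is the earlier exchange of one aryl group for another on the same amide-type nitrogen, no change at the digits printed from compound 2 to compound 3 (within the scatter). The two replacements of the 3-methylbut-2-en-1-yl group by a carbamoyl group, a number 7.5 percentage points lower from compound 1 to compound 2 (within the scatter) and a number 7.5 percentage points lower from compound 1 to compound 3 (within the scatter), were also within the scatter. Within the data shown here, nothing among the measured compounds indicates that altering the aryl group on the nitrogen shifts the read-out, so no step beyond the scatter is expected in this assay. For compound 4 the expected step is a number 2 percentage points higher from compound 3 to compound 4 (within the scatter). Compound 4 is therefore estimated to give 2%, with a range from 0% to 12%.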

Compound 4, a percentage reported as inhibition, at one concentration (the size of the read-out at that concentration, not a potency): 1.8%
Estimate against measurement, compound 4: 0.2 percentage points above; the measured number falls inside the stated range.
By their numbers in this assay, from the lowest: compounds 2, 3, 4 and 1 (each within the scatter of the next).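

In this assay a third aryl group on the amide-type nitrogen, 3,4-dichlorophenyl, cannot be told apart from the other two, with a number 1.8 percentage points higher from compound 3 to compound 4 (within the scatter) and a number 1.8 percentage points higher from compound 2 to compound 4 (within the scatter) for the two exchanges, so moving from fluorine to chlorine, with a different substitution pattern on the ring, still produces no readable change at this position. The carbamoyl exchange on the oxygen reads the same way with this third aryl group, at a number 5.7 percentage points lower from compound 1 to compound 4 (within the scatter) against the 3-methylbut-2-en-1-yl ether, so the four compounds remain within the scatter of one another and no order among them can be claimed. No measurement at hand offers an explanation for these numbers.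

The compounds shown leave open whether any group on this nitrogen could carry the read-out clear of the scatter, for example a butyl chain, a benzyl group, or a phenyl ring bearing a carboxylic acid or an amine. They also leave open whether a plain acetyl group on the oxygen, in place of the carbamoyl link, would separate from these compounds at all.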